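A few compounds are considered here, and "the series" means these few. Any claim that something is new, unique, unknown or untested is made for them only; others in the source may bear on it.

Series notes. Compound 1 `Cc1cccc(Nc2ncc(C)c(Nc3ccc4nc[nH]c4c3)n2)c1` and compound 2 `Cc1cccc(Nc2ncc(Cl)c(Nc3ccc4nc[nH]c4c3)n2)c1` share one core; compound 3 `NS(=O)(=O)c1ccc(Nc2ncc(Cl)c(Nc3ccc4nc[nH]c4c3)n2)cc1` and compound 4 `Cc1cnc(Nc2ccc(S(N)(=O)=O)cc2)nc1Nc1ccc2nc[nH]c2c1` share another, and the difference between the two cores is not broken down here. In an ADME assay on HepG2 cells (Homo sapiens) for inhibition, read by fluorescence and resazurin assay, with a stated time of 72 h (on this read-out lower numbers stand for stronger inhibition and higher numbers for weaker inhibition), compound 1 gives 6600 nM. In this assay compound 2 gives 7400 nM, and in this assay compound 3 gives 7800 nM; these three numbers sit within the scatter of one another. The change methyl in place of chloro on an aromatic carbon yields a 1.1-fold lower number from compound 2 to compound 1 (0.05 log units; within the scatter). Compound 4 carries the same kind of change, (methyl in place of chloro on an aromatic carbon); the place differs in that it is described as para to a large group rather than para to a (3-methylphenyl)amino group (8 heavy atoms). Because the measured step of a 1.1-fold lower number from compound 2 to compound 1 (0.05 log units; within the scatter) is small, the step of a 1.1-fold lower number from compound 3 to compound 4 (0.05 log units; within the scatter) is expected to be similarly small. Compound 4 is therefore estimated at 7000 nM, between 3500 nM and 14000 nM.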

Compound 4, half-maximal inhibitory concentration: 18000 nM
For compound 4 the middle estimate is 2.6-fold (0.41 log units) below the measured one; the whole stated range lies below it.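

In this assay methyl in place of chloro on an aromatic carbon gives a 2.3-fold higher number from compound 3 to compound 4 (0.36 log units; beyond the scatter) on the core of compound 3, a modest step. Set beside the earlier step, this result does not separate the two cores: the same change on two cores in this assay, a 1.1-fold lower number (0.05 log units; within the scatter) from compound 2 to compound 1 and a 2.3-fold higher number (0.36 log units; beyond the scatter) from compound 3 to compound 4, 2.6-fold (0.41 log units) apart, within the scatter of two such steps. For the compounds shown here, it shows no difference between the cores that exceeds the scatter, but with only two pairs it does not show that the change carries over unaltered, nor that the core alters it.

From the compounds shown here alone, how fluoro, a nitrile or an amine on that aromatic carbon would read in this assay stays open on both cores. Also open, going by these compounds, is whether a longer chain there would follow the same course as methyl.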